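The source may hold more compounds than are shown below. What is called first, only, known or untested is meant among the compounds shown, and "the series" means these compounds.

Compound 3, with the structure `COc1cc(-c2ccnc3cc(-c4ccc(F)cc4)nn23)cc(OC)c1OC`, is the weaker of the two compounds that gave a number in a functional assay on A549 cells (Homo sapiens) for inhibition, read by CCK-8 assay, with a stated time of 48 h (on this read-out higher numbers stand for weaker inhibition and lower numbers for stronger inhibition), where compound 3 gives 3800 nM. Its nearest measured neighbour is compound 1, with the structure `COc1cc(-c2ccnc3cc(-c4c[nH]c5ccccc45)nn23)cc(OC)c1OC`, which gives 29 nM in this assay; the change of 1H-indol-3-yl to 4-fluorophenyl on an aromatic carbon brings a 130-fold higher number from compound 1 to compound 3 (2.12 log units; beyond the scatter). Compound 2, with the structure `CCOC(=O)c1ccc(-c2cc3nccc(-c4cc(OC)c(OC)c(OC)c4)n3n2)cc1`, reaches only the limit of this assay, > 10000 nM, which is not a number. Replacing ethoxycarbonyl by fluoro on an aromatic carbon gives an at least 2.6-fold lower number from compound 2 to compound 3 (0.42 log units; beyond the scatter).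

Compound 4, with the structure `COc1cc(-c2ccnc3cc(-c4ccc(C(F)(F)F)cc4)nn23)cc(OC)c1OC`, differs from compound 3 in one place: trifluoromethyl in place of fluoro on an aromatic carbon. Neither measured step repeats this change. The step from compound 1 to compound 3 swaps the whole ring and says little here. The step from compound 2 to compound 3 changes the group at the same place, para to a large group, and there a larger group sat at the limit while fluoro gave a number, so a larger group entering is expected to weaken inhibition by a modest step, a 1.8-fold higher number from compound 3 to compound 4 (0.27 log units; within the scatter). Compound 4 is therefore estimated at 7000 nM, with a likely range from 2000 nM to 20000 nM.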

Compound 4, half-maximal inhibitory concentration: 2070 nM
Beside the measured number, compound 4's estimate is 3.4-fold (0.53 log units) above it, and the stated range covers the measured number.
By their numbers in this assay, from the lowest: compound 1; then compounds 4 and 3 (each within the scatter of the next). At a limit, above all of these: compound 2.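

Where the ring carries its group para to a large group, replacing fluoro with trifluoromethyl gives a 1.8-fold lower number from compound 3 to compound 4 (0.26 log units; within the scatter), so compound 3 and compound 4 cannot be told apart, even though the entering group has 4 heavy atoms and the leaving one has 1. Among these compounds, this is the first sign that this place tolerates a change of group without a clear shift in the number, at least for these two groups. Trifluoromethyl in place of ethoxycarbonyl gives an at least 4.8-fold lower number from compound 2 to compound 4 (0.68 log units; beyond the scatter), but this step starts from a limit and not from a number, so it shows only that compound 4 stays within the measurable range: the limit of > 10000 nM in this assay, at which 1 of the 4 values shown sits. Swapping the whole ring still matters far more, with a 71-fold higher number from compound 1 to compound 4 (1.85 log units; beyond the scatter), so neither group on the phenyl ring comes close to what 1H-indol-3-yl gives.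

The compounds shown leave open whether an amine, a hydroxyl or a methoxy group at this place would move the number beyond the scatter. They also leave open whether a plain phenyl ring, with only hydrogen at this place, would sit with compound 3 and compound 4 or closer to compound 1.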